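The compounds below may be only part of what the source reports. "The series", "measured", "known", "first", "only" and "open" are said of these compounds alone.

Compound 1 `O=C(NCCCCc1ccccc1)n1c(=O)oc2cc(Br)ccc21` gives 31 nM in an assay on HEK293 cells for inhibition of acid ceramidase (Homo sapiens), with a stated time of 10 min; a lower number here means a stronger inhibitor, a higher number a weaker inhibitor.
Compound 2 `O=C(NCCCCc1ccccc1)n1c(=O)oc2cc(F)ccc21` gives 31 nM in this assay.

On these numbers compound 2 stands level with compound 1. Among the compounds with values here, the only measured step, no change at the digits printed from compound 1 to compound 2 (within the scatter), exchanged one halogen for another and left potency unchanged within the scatter. Compound 3 `O=C(c1ccc(Cl)cc1)c1ccc2c(c1)oc(=O)n2C(=O)NCCCCc1ccccc1` differs from compound 2 by (4-chlorophenyl)carbonyl in place of fluoro on an aromatic carbon. Within the data shown here, no measured step adds a group of this kind, so the halogen swap bears on it only weakly, and nothing here points to a step in this assay in either direction beyond the scatter. Compound 3 is therefore expected at 20 nM, within 4 nM to 100 nM. This amounts to an expected step of a 1.6-fold lower number from compound 2 to compound 3 (0.19 log units; within the scatter).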

Compound 3, half-maximal inhibitory concentration: 14 nM
The estimate for compound 3 lay 1.4-fold (0.15 log units) above the measured number; low and high end bracket the measured number.
By their numbers in this assay, from the lowest: compound 3; then compounds 1 and 2 (each within the scatter of the next).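

Putting the much larger (4-chlorophenyl)carbonyl on this aromatic carbon in place of a single halogen atom gives, in this assay, a 2.2-fold lower number from compound 2 to compound 3 (0.35 log units; beyond the scatter) and a 2.2-fold lower number from compound 1 to compound 3 (0.35 log units; beyond the scatter) as a modest gain rather than a loss. The two halogens alone could not show that this carbon accepts a group holding a whole aromatic ring and a carbonyl. Nothing measured here explains the gain. On these data alone, whether it rests on the carbonyl, the ring or the chlorine stays open, as does how an amine or a carboxylic acid on this carbon would compare.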